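This account rests on a few compounds, and the source may have more. Where it says the series, first, only, none or still open, it means among the compounds named here.

Compound 1 `COc1ccc(-c2cc(/C=C/C(=O)c3ccc(N)cc3)[nH]n2)cc1`: 97%
Compound 2 `COc1cc(-c2cc(/C=C/C(=O)c3ccc(N)cc3)[nH]n2)cc(OC)c1OC`: 99%

For the measured compounds named here, in a functional assay on SF-539 cells (Homo sapiens) for cytotoxicity, read by sulforhodamine B assay, with a stated time of 48 h, tested at 0.1 uM (on this read-out higher numbers stand for a weaker effect at the one concentration tested and lower numbers for a stronger effect), compound 2 gives 99%, the higher of the two numbers so far. Compound 1 gives 97%, and the gap to compound 2 lies within the scatter, so the two cannot be placed in order. Both numbers mean that at this concentration neither compound holds the cells back to any notable degree.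

Compound 3 `COc1ccc(-c2cc(/C=C/C(=O)c3ccc(N)cc3)[nH]n2)cc1OC` differs from compound 2 in one place:
hydrogen in place of methoxy on an aromatic carbon

Going by the values given here, no step between two measured compounds is available, so there is no recorded step of this kind to lean on. The expectation rests on compound 2 giving 99% and compound 1 giving 97%, both close to the top of the scale, and the step expected from compound 2 to compound 3 is a number 1 percentage points lower from compound 2 to compound 3 (within the scatter), none beyond the scatter. Compound 3 is estimated to give about 98% in this assay, with a range from 86% to 100%.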

Compound 3, a percentage reported as activity, at one concentration (the size of the read-out at that concentration, not a potency): 97%
Estimate against measurement, compound 3: 1 percentage points above, and the stated range covers the measured number.
By their numbers in this assay, from the lowest: compounds 1, 3 and 2 (each within the scatter of the next).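

In this assay, hydrogen in place of methoxy on this aromatic carbon gives a number 2 percentage points lower from compound 2 to compound 3 (within the scatter), and methoxy in place of hydrogen on an aromatic carbon gives no change at the digits printed from compound 1 to compound 3 (within the scatter). This carbon, ortho to a methoxy group and meta to a large group, therefore shows no readable effect of carrying a methoxy or a hydrogen. The other change tells the same story, so all three compounds stay together near the top of the scale, and none can be placed ahead of another. Nothing at hand explains this flat result.

Going by these compounds, whether a different group on this carbon, such as an amine, a fluorine atom or a carboxylic acid, would move the number remains open. So does whether these compounds would separate at a higher concentration.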